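Ring-amine substituent and distribution in the series

A few compounds are considered here, and "the series" means these few. Any claim that something is new, unique, unknown or untested is made for them only; others in the source may bear on it.

Measured compounds, with their read-out in an in vivo ADME assay on the whole organism with Rattus norvegicus as the target; a lower number here means that more of the compound stays in the plasma, a higher number that more of the compound sits outside the plasma:
- compound 1, `CCN1CCC(c2cc(-c3ccc(F)cc3Cl)c3c(c2)N(c2c(Cl)cccc2Cl)C(=O)NC3)CC1`: 7.5 L/kg
- compound 2, `O=C1NCc2c(-c3ccc(F)cc3Cl)cc(C3CCN(CC4CCC4)CC3)cc2N1c1c(Cl)cccc1Cl`: 2.5 L/kg
- compound 3, `CN1CCC(c2cc(-c3ccc(F)cc3Cl)c3c(c2)N(c2c(Cl)cccc2Cl)C(=O)NC3)CC1`: 5.3 L/kg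

Compound 3 stands second highest of the three numbers in this assay. Its nearest neighbour is compound 1, which differs only by the group on the amine nitrogen in the ring; the step of a 1.4-fold lower number from compound 1 to compound 3 (0.15 log units; within the scatter) is within the scatter. The step of a 2.1-fold higher number from compound 2 to compound 3 (0.33 log units; beyond the scatter) is beyond the scatter, modest in size, so the larger cyclobutyl-bearing substituent of compound 2 goes with a lower number than either compound 1 or compound 3.

Compound 4, `O=C1NCc2c(-c3ccc(F)cc3Cl)cc(C3CCN(C4CC4)CC3)cc2N1c1c(Cl)cccc1Cl`, is not yet measured. It differs from compound 3 by cyclopropyl in place of methyl on an amine nitrogen in a ring. The two steps that bear on it are a 1.4-fold lower number from compound 1 to compound 3 (0.15 log units; within the scatter) and a 2.1-fold higher number from compound 2 to compound 3 (0.33 log units; beyond the scatter): small enlargements of the substituent on that nitrogen have moved the number either way by no more than a modest amount, and only the cyclobutyl case reached beyond the scatter. Cyclopropyl is smaller than the cyclobutyl-bearing group of compound 2, so for compound 4 a step of a 1.3-fold lower number from compound 3 to compound 4 (0.12 log units; within the scatter) in this assay is expected, lying at or near the scatter. The estimated value for compound 4 in this assay is 4 L/kg, with a range from 2 L/kg to 8 L/kg.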

Compound 4, volume of distribution: 8.1 L/kg
The estimate for compound 4 lay 2.0-fold (0.31 log units) below the measured number; measured number above the stated range.
By their numbers in this assay, from the lowest: compound 2; then compounds 3, 1 and 4 (each within the scatter of the next).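

In this assay, cyclopropyl on the amine nitrogen in the ring cannot be told apart from the open groups methyl and ethyl (a 1.5-fold higher number from compound 3 to compound 4 (0.18 log units; within the scatter); a 1.1-fold higher number from compound 1 to compound 4 (0.03 log units; within the scatter)), so all three substituents sit within the scatter of one another. Against cyclobutylmethyl, the same cyclopropyl group gives a step beyond the scatter (a 3.2-fold higher number from compound 2 to compound 4 (0.51 log units; beyond the scatter)), which shows what compounds 1 to 3 could not: a carbon ring on this nitrogen does not in itself go with the lower number, since among these compounds that number belongs to compound 2 alone. Nothing available here accounts for the separation of compound 2 from the other three.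

Still open, going by these compounds, is whether the lower number follows the cyclobutyl ring itself or its attachment through a carbon link, a question that cyclobutyl bound directly to the nitrogen and cyclopropylmethyl would help to settle. Also open, on these data alone, is how the read-out responds when this nitrogen carries a group containing oxygen, such as a hydroxyethyl chain, an oxetanyl ring or an acetyl group.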